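The source may report more compounds than this note shows. Statements on the series, on what has been measured and on what is new or still open speak of the compounds shown alone.

The account follows one change, from compound 2 to compound 3, and sets it beside the only numbered result in this series. Compound 1 `Cc1ccc(C2CNN=C2S(=O)(=O)CC2=NCCS2)cc1` is measured in a functional assay, tested at 75 ug/mL (on this read-out lower numbers stand for a weaker effect and higher numbers for a stronger effect at the one concentration tested), and gives 42.2%. Compound 2 `O=S(=O)(CC1=NCCO1)C1=NNCC1c1ccccc1` is tested in this assay and is reported as "not active" (no number reported); no number accompanies that report, so compound 2 stands below anything that can be placed on the scale, and the gap between compound 2 and compound 1 can be read only as the difference between an unquantified result and a measured one. Compound 3 `Cc1ccc(C2CNN=C2S(=O)(=O)CC2=NCCO2)cc1` is not yet measured in this assay. It differs from compound 2 by methyl in place of hydrogen on an aromatic carbon. Compound 1 carries the same methyl group, so the two measured compounds do not bracket compound 3 cleanly; the change is small and, on its own, offers no ground for a step beyond the scatter, while the value of compound 1 leaves room for a modest effect. Compound 3 is therefore expected to give about 20%, estimated within 0% to 45%, with a real chance that only an inactive report is returned.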

Compound 3, a percentage reported as activity, at one concentration (the size of the read-out at that concentration, not a potency): 42.1%
Estimate against measurement, compound 3: 22.1 percentage points below; the range from low to high includes it.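

Going from phenyl to 4-methylphenyl, on an aromatic carbon para to a large group, separates compound 2, reported as not active with no number, from compound 3, which gives 42.1% in this assay; the step cannot be read as a size, but it shows that this one methyl marks the difference between an inactive report and a measured effect at the one concentration tested. The exchange of the sulfur-containing five-membered non-aromatic ring for the oxygen-containing one, on a saturated chain carbon bound to a sulfonyl sulfur, gives a number 0.1 percentage points lower from compound 1 to compound 3 (within the scatter), so with 4-methylphenyl in place, this exchange cannot be told apart from the scatter. Nothing given here bears on the reason for either result.

The compounds shown leave open whether a chlorine atom, a methoxy group or a longer chain at the same aromatic carbon would give a read-out like that of methyl. They also leave open whether the sulfur-containing ring, carried on an unsubstituted phenyl compound, would share the inactive report of compound 2.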